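The source may report more compounds than this note shows. Statements on the series, on what has been measured and on what is new or still open speak of the compounds shown alone.

Measured so far in a functional assay on CCRF-CEM cells (Homo sapiens) for antiproliferative activity, with a stated time of 72 h; a higher number here means a weaker inhibitor, a lower number a stronger inhibitor:
compound 1 `COc1ccc(-n2c(-c3cc(OC)c(OC)c(OC)c3)c(Cl)sc2=O)cc1` gives 13800 nM
compound 2 `COc1ccc(-c2csc(=O)n2-c2cc(OC)c(OC)c(OC)c2)cc1` gives 1800 nM
compound 3 `COc1ccc(-n2c(-c3cc(OC)c(OC)c(OC)c3)c(Cl)sc2=O)cc1[N+](=O)[O-]` gives only a limit, > 20000 nM

Compound 2 has the lower of the two plain numbers, and its gap to compound 1 is beyond the usual scatter of repeated measurements. How the core of compound 1 and the core of compound 2 differ is not broken down here; they differ in more than one place.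

Going by the values given here, the one single-point change with a measured outcome is nitro in place of hydrogen on an aromatic carbon. In this assay it gave an at least 1.4-fold higher number from compound 1 to compound 3 (0.16 log units; that floor lies within the scatter). Compound 3 is the value that sits at the limit of > 20000 nM in this assay, at which 1 of the 3 values shown sits. The true size of that step is therefore hidden above the floor; only its lower edge is known, and that edge lies within the scatter.

Compound 4 `COc1ccc(-c2csc(=O)n2-c2cc(OC)c(OC)c(OC)c2)cc1[N+](=O)[O-]` is not yet measured. It differs from compound 2 by nitro in place of hydrogen on an aromatic carbon. The surroundings of the place are the same word for word as for the step from compound 1 to compound 3, so this is the same change, now on the more potent core.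

The expectation rests on that one measured step, a floor rather than a number. The step from compound 2 to compound 4 is expected to be a 2.8-fold higher number from compound 2 to compound 4 (0.44 log units; beyond the scatter). Compound 4 is accordingly estimated at 5000 nM, with a range from 1800 nM to 20000 nM, and some chance that this assay returns only a limit.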

Compound 4, half-maximal inhibitory concentration: 8200 nM
Compound 4: the middle estimate sits 1.6-fold (0.21 log units) below what was measured; the measured number falls inside the stated range.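

On the core of compound 2, nitro in place of hydrogen on an aromatic carbon gives, in this assay, a 4.6-fold higher number from compound 2 to compound 4 (0.66 log units; beyond the scatter), so on this core the change clearly costs activity. On the core of compound 1 the same change is known only as a floor, so the notes can claim neither a matching size nor a different one, and two cores would not support a general rule for the series in any case: the same change on two cores in this assay, an at least 1.4-fold higher number (0.16 log units; that floor lies within the scatter) from compound 1 to compound 3 and a 4.6-fold higher number (0.66 log units; beyond the scatter) from compound 2 to compound 4; the limit leaves it open whether they differ

Compound 3 gives > 20000 nM, which is a limit of the assay and not a number.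

Still open is whether the loss on the core of compound 2 belongs to nitro itself or would follow any group placed ortho to the methoxy group, since an amine, a nitrile, a fluorine atom or a carboxylic acid at that place is not among the compounds shown. Also open, from the compounds shown here alone, is whether the step seen on the core of compound 2 would hold on a third core, which would show how far this change can be carried across the series.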